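Swapping the pyridine ether for a chlorophenyl ether

The compounds below may be only part of what the source reports. "The series", "measured", "known", "first", "only" and "open" are said of these compounds alone.

Of the compounds shown here, three have been tested in an ADME assay on PBMC cells (Homo sapiens) for cytotoxicity; on this read-out higher numbers stand for lower toxicity in this test and lower numbers for higher toxicity in this test. Compound 1 `CC(CCNC(=O)c1c(Cl)cncc1Cl)N1CCC(C(=O)c2ccc(Br)cc2)CC1` gives 189000 nM in this assay. Compound 2 `Cc1cccc(OC(c2ccc(C(F)(F)F)cc2)C2CCN(C(C)CCNC(=O)c3c(Cl)cncc3Cl)CC2)n1` gives 6700 nM in this assay, the lowest of the two plain numbers, and the gap to compound 1 lies beyond the usual scatter, so compound 2 is the more toxic of the pair. Compound 3 `CCO/N=C(/c1ccc(Br)cc1)C1CCN(C(C)CCN(C)C(=O)c2c(C)cc[n+]([O-])c2C)CC1` reaches only a limit of the assay, > 182000 nM, and not a number. For compound 3 this reading is the limit of > 182000 nM in this assay, at which 1 of the 3 values shown sits.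

Compound 4 `CC(CCNC(=O)c1c(Cl)cncc1Cl)N1CCC(C(Oc2cccc(Cl)c2)c2ccc(C(F)(F)F)cc2)CC1` has not yet been measured. It differs from compound 2 in one place: 3-chlorophenyl in place of 6-methylpyridin-2-yl on an oxygen on a saturated carbon. For the measured compounds named here, with no measured pair showing this kind of exchange, the expectation rests on compound 2 alone, whose value of 6700 nM is the starting point. The step from compound 2 to compound 4 is expected to be small, within the usual scatter, amounting to a 1.3-fold lower number from compound 2 to compound 4 (0.13 log units; within the scatter). Compound 4 is therefore estimated at 5000 nM in this assay, most likely between 1500 nM and 20000 nM.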

Compound 4, half-maximal cytotoxic concentration: 8100 nM
Compound 4: the middle estimate sits 1.6-fold (0.21 log units) below what was measured, and the stated range covers the measured number.
By their numbers in this assay, from the lowest: compounds 2 and 4 (each within the scatter of the next); then compound 1.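

Exchanging 6-methylpyridin-2-yl for 3-chlorophenyl on this oxygen gives a 1.2-fold higher number from compound 2 to compound 4 (0.08 log units; within the scatter) in this assay. At this position, then, a carbon-only aromatic ring carrying a chlorine stands in for a methylated pyridine ring with no change beyond the scatter, even though the exchange removes the ring nitrogen and its hydrogen-bond acceptor. Nothing among the measurements shown explains why this exchange leaves the reading so close.

The compounds shown leave open how an unsubstituted phenyl ring, or a ring bearing an amine or a carboxylic acid, would read on this oxygen. They also leave open whether the same exchange would behave alike on a different core, such as that of compound 3.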